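Lengthening the Side Chain of an Antiproliferative Ester

The source may hold more compounds than are shown below. What is called first, only, known or untested is meant among the compounds shown, and "the series" means these compounds.

Compound 1 `CCCC(C#CC(=O)OC)O/C=C/C(=O)OC` was tested in a functional assay on SW1573 cells (Homo sapiens) for antiproliferative activity, read by sulforhodamine B assay, with a stated time of 48 h (on this read-out lower numbers stand for stronger inhibition of growth and higher numbers for weaker inhibition of growth), and gives 320 nM. Of the three measured compounds it has the lowest number: compound 3 `COC(=O)C#CC(CC(C)C)O/C=C/C(=O)OC` gives 380 nM and compound 2 `COC(=O)C#CC(O/C=C/C(=O)OC)C1CC1` gives 1800 nM. The step of a 1.2-fold higher number from compound 1 to compound 3 (0.07 log units; within the scatter) stays within the scatter, whereas a 5.6-fold higher number from compound 1 to compound 2 (0.75 log units; beyond the scatter) lies beyond it. Compound 4 `CCCCCCCCCCC(C#CC(=O)OC)O/C=C/C(=O)OC` differs from compound 1 in one place: heptyl in place of hydrogen on a saturated chain carbon, four bonds along the chain from an oxygen on an unsaturated carbon and a triple-bonded carbon. Among the measured compounds shown here, only the step to compound 3, which also adds carbon to the chain, bears on this, and it was within the scatter; no measured step shows so large an extension of the chain. Compound 4 is therefore expected to land near compound 1, estimated at 400 nM with a range from 120 nM to 1500 nM, a step of a 1.3-fold higher number from compound 1 to compound 4 (0.10 log units; within the scatter).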

Compound 4, concentration for 50% growth inhibition: 2000 nM
The estimate for compound 4 lay 5.0-fold (0.70 log units) below the measured number, and the stated range ends below it.
By their numbers in this assay, from the lowest: compounds 1 and 3 (each within the scatter of the next); then compounds 2 and 4 (each within the scatter of the next).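

Heptyl at this place gives a 6.3-fold higher number from compound 1 to compound 4 (0.80 log units; beyond the scatter), so growth inhibition here does not hold up however far the chain is extended. The small methyl addition gave only a 1.2-fold higher number from compound 1 to compound 3 (0.07 log units; within the scatter), and only this much larger addition shows that the side chain has a limit. No measurement shown explains this weakening.

The compounds shown leave open at what length the loss sets in, for instance with a pentyl or hexyl chain. They also leave open whether an amine or a carboxylic acid in place of heptyl would restore growth inhibition.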